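Ring Size at the Amine and Receptor Binding

The source may hold more compounds than are shown below. What is called first, only, known or untested is meant among the compounds shown, and "the series" means these compounds.

Compound 1 `Cc1cc(F)ccc1[C@H]1C[C@@H](N(C)C)CCN1C(=O)N(C)Cc1cc(C(F)(F)F)cc(C(F)(F)F)c1` and compound 2 `Cc1cc(F)ccc1[C@H]1C[C@@H](N2CCC2)CCN1C(=O)N(C)Cc1cc(C(F)(F)F)cc(C(F)(F)F)c1` share one core and differ only in the amine attached to the saturated ring. In an assay on CHO cells for displacement of a labelled ligand from Substance-P receptor (Homo sapiens), read by scintillation counting (on this read-out lower numbers stand for stronger inhibition and higher numbers for weaker inhibition), compound 1 gives 0.0794 nM and compound 2 gives 0.0813 nM. The step of a 1.0-fold higher number from compound 1 to compound 2 (0.01 log units; within the scatter) shows that exchanging dimethylamino for azetidin-1-yl left the number essentially where it was. Compound 2 carries the higher of the two numbers on paper, but its gap to compound 1 lies within the scatter, so the two cannot be told apart. Compound 3 `Cc1cc(F)ccc1[C@H]1C[C@@H](N2CCCC2)CCN1C(=O)N(C)Cc1cc(C(F)(F)F)cc(C(F)(F)F)c1` continues the same line of thought: pyrrolidin-1-yl in place of azetidin-1-yl on a saturated ring carbon. Among the measured compounds shown here, only one measured step bears on this change, namely a 1.0-fold higher number from compound 1 to compound 2 (0.01 log units; within the scatter), and it was flat. Since the earlier change at this position produced no shift beyond the scatter, the move from the four-membered to the five-membered ring is expected to behave alike, giving a step of a 1.0-fold higher number from compound 2 to compound 3 (0.02 log units; within the scatter). Compound 3 is therefore estimated at 0.085 nM in this assay, with a likely range from 0.03 nM to 0.25 nM.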

Compound 3, inhibition constant: 0.275 nM
Compound 3: the middle estimate sits 3.2-fold (0.51 log units) below what was measured; measured number above the stated range.
By their numbers in this assay, from the lowest: compounds 1 and 2 (each within the scatter of the next); then compound 3.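

In this assay, this position on the saturated ring carbon proves sensitive to the choice of amine: the ring change gives a 3.4-fold higher number from compound 2 to compound 3 (0.53 log units; beyond the scatter) and so moves the number beyond the scatter, even though the group stays a simple cyclic amine with the same count of hydrogen-bond donors and acceptors. Compared with the open-chain dimethylamino group, pyrrolidin-1-yl gives a 3.5-fold higher number from compound 1 to compound 3 (0.54 log units; beyond the scatter) and again lies beyond the scatter, so compound 3 stands apart from both compound 1 and compound 2, which cannot be told apart from each other. The flat result for dimethylamino and azetidin-1-yl therefore held only for that pair of groups and did not extend to the five-membered ring, showing that one unchanged step at a position does not settle how the next group there will behave.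

Nothing available here explains why the number rises with the five-membered ring. On these data alone, it also remains open whether a six-membered piperidin-1-yl would raise the number further, and whether morpholin-4-yl, with an oxygen in its ring, would behave in the same way at this position.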